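A few compounds are considered here, and "the series" means these few. Any claim that something is new, unique, unknown or untested is made for them only; others in the source may bear on it.

Of the compounds shown here, three have so far been measured in an ADME assay on S9 fraction from liver (Mus musculus, strain ICR/CD-1) for metabolic stability, read by LC-MS, using NADPH, with a stated time of 5 min, tested at 2 uM; a lower number here means that the compound disappears faster, a higher number that the compound lasts longer. Compound 1 `CC1CCN(C2CCN(S(=O)(=O)c3cccc(-c4ccc(F)cc4)c3)CC2)CC1` gives 1.28 h, the highest of the three numbers. Compound 3 `CC1CCN(C2CCN(S(=O)(=O)c3ccc(Cl)c(Cl)c3)CC2)CC1` gives 0.55 h, a number that sits below that of compound 1 by more than the usual scatter of this kind of measurement. Compound 2 `CC1CCN(C2CCN(S(=O)(=O)c3cc(Br)cc4c3OCC4)CC2)CC1` gives 0.0833 h, the lowest of the three and far below compound 1. Compound 4 `Cc1ccc(-c2cccc(S(=O)(=O)N3CCC(N4CCC(C)CC4)CC3)c2)cc1` has not yet been measured in this assay. It differs from compound 1 in a single place: methyl in place of fluoro on an aromatic carbon. Within the data shown here, no measured pair shows this same exchange, so the size of its effect has to be guessed rather than read from the data. The expected step of a 2.0-fold lower number from compound 1 to compound 4 (0.29 log units; within the scatter) is a moderate fall, of a size that may reach beyond the scatter but should leave compound 4 still well above compound 2. Compound 4 is therefore expected to give about 0.65 h, with a likely range from 0.25 h to 1.6 h.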

Compound 4, half-life: 1.92 h
Beside the measured number, compound 4's estimate is 3.0-fold (0.47 log units) below it; measured number above the stated range.
By their numbers in this assay, from the lowest: compound 2; then compound 3; then compounds 1 and 4 (each within the scatter of the next).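

In this assay, swapping 4-fluorophenyl for 4-methylphenyl gives a 1.5-fold higher number from compound 1 to compound 4 (0.18 log units; within the scatter), so at this place, para to a large group, fluoro and methyl cannot be told apart by half-life. Among these compounds, the earlier compounds could not show this, since no two of them differed in only one place; this step is the first to isolate a single position on the shared core. Nothing available explains why the two groups give such similar numbers.

As far as these compounds go, it remains open whether a methoxy group, an amine, a carboxylic acid or a longer chain at this same place would also stay within the scatter of compound 1. Also open, from the compounds shown here alone, is whether methyl in place of fluoro would behave the same way on another aromatic carbon of this series.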